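This account rests on a few compounds, and the source may have more. Where it says the series, first, only, none or still open, it means among the compounds named here.

Among the measured compounds shown here, compound 2 `OC[C@H]1O[C@@H](n2cnc3c(NCc4ccc(Cl)cc4Cl)ncnc32)[C@H](O)[C@@H]1O` gives 127000 nM in a functional assay on MCF cells (Homo sapiens) for antiproliferative activity, with a stated time of 72 h (on this read-out higher numbers stand for weaker inhibition and lower numbers for stronger inhibition), the highest of the two numbers so far; compound 1 `OC[C@H]1O[C@@H](n2cnc3c(NCc4cccc(F)c4)ncnc32)[C@H](O)[C@@H]1O` gives 15300 nM. For the measured compounds named here, the one measured step at this place, an 8.3-fold higher number from compound 1 to compound 2 (0.92 log units; beyond the scatter), shows that swapping the aryl group there can move the number well beyond the scatter. Compound 3 `COc1cccc(CNc2ncnc3c2ncn3[C@@H]2O[C@H](CO)[C@@H](O)[C@H]2O)c1O` carries another such swap: 2-hydroxy-3-methoxyphenyl in place of 2,4-dichlorophenyl on a saturated chain carbon bound to a nitrogen on an aromatic ring. Going by the values given here, no step with a hydroxy or methoxy group exists here, so the direction is open. Compound 3 is expected to give about 60000 nM in this assay, with a range of 15000 nM to 250000 nM, which means an estimated step of a 2.1-fold lower number from compound 2 to compound 3 (0.33 log units; beyond the scatter).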

Compound 3, half-maximal inhibitory concentration: 20200 nM
Beside the measured number, compound 3's estimate is 3.0-fold (0.47 log units) above it, within the range that was stated.
By their numbers in this assay, from the lowest: compounds 1 and 3 (each within the scatter of the next); then compound 2.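

In this assay, 2-hydroxy-3-methoxyphenyl in place of 2,4-dichlorophenyl gives a 6.3-fold lower number from compound 2 to compound 3 (0.80 log units; beyond the scatter) at this place on the chain carbon, so the earlier step is not specific to fluorine-bearing aryl groups. Against 3-fluorophenyl the change gives a 1.3-fold higher number from compound 1 to compound 3 (0.12 log units; within the scatter) and the two compounds cannot be told apart, which leaves 2,4-dichlorophenyl alone at the high end of these three. Nothing measured here accounts for these steps.

Which of the hydroxy and methoxy groups matters stays open, as they enter together. An aminophenyl group or a longer chain at this place also remains untested in what is shown.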